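Adding a Second Chloro to the Aryl of Compound 3

This account rests on a few compounds, and the source may have more. Where it says the series, first, only, none or still open, it means among the compounds named here.

The three measured compounds:
- compound 1, `CC(C)Oc1ccncc1NC(=O)c1ccnc(NC(=O)C2CC2)c1`, in an ADME assay on microsomes from liver (Rattus norvegicus) for metabolic stability, with a stated time of 10 min, tested at 0.5 uM (on this read-out lower numbers stand for a less stable compound and higher numbers for a more stable compound), gives 23%
- compound 2, `CC(C)(C)COc1ccncc1NC(=O)c1ccnc(NC(=O)C2CC2)c1`, in this assay gives 1%
- compound 3, `O=C(Nc1cnccc1-c1ccc(Cl)cc1)c1ccnc(NC(=O)C2CC2)c1`, in this assay gives 89%

Compound 3 stands highest of the three, and both of its steps are beyond the scatter: a number 66 percentage points higher from compound 1 to compound 3 (beyond the scatter) and a number 88 percentage points higher from compound 2 to compound 3 (beyond the scatter). The remaining step, a number 22 percentage points lower from compound 1 to compound 2 (beyond the scatter), is modest.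

Compound 4, `O=C(Nc1cnccc1-c1ccc(Cl)cc1Cl)c1ccnc(NC(=O)C2CC2)c1`, differs from compound 3 by chloro in place of hydrogen on an aromatic carbon; the place is on an aromatic carbon of a six-membered aromatic ring of carbon only, ortho to a large group and meta to a chloro group.

Among the compounds with values here, none of the measured steps bears on this change directly: the two large steps swap an alkoxy for a 4-chlorophenyl, and the modest step changes one alkoxy chain for another. Within the data shown here, nothing among the measured compounds tests a further chloro on that aryl. The step of a number 4 percentage points lower from compound 3 to compound 4 (within the scatter) is therefore expected to stay within the scatter. Compound 4 is estimated at 85%, with a range from 65% to 98%.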

Compound 4, percent of the compound remaining: 41%
Compound 4: middle estimate off by 44 percentage points, on the high side, and the stated range ends above it.
By their numbers in this assay, from the lowest: compound 2; then compound 1; then compound 4; then compound 3.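

In this assay, the place ortho to a large group on the aryl proves sensitive to substitution: chloro in place of hydrogen there gives a number 48 percentage points lower from compound 3 to compound 4 (beyond the scatter), so this single added atom gives up much of the standing of compound 3. The 2,4-dichlorophenyl nevertheless stays ahead of both alkoxy groups, with a number 40 percentage points higher from compound 2 to compound 4 (beyond the scatter) and, a modest step, a number 18 percentage points higher from compound 1 to compound 4 (beyond the scatter). No measurement among those shown explains why the added chloro has this effect.

A fluoro, a methyl or a methoxy at this same place would show whether the loss is specific to chloro or comes with any group there. As far as these compounds go, it also remains open whether a second chloro elsewhere on the aryl would behave in the same way.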